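This account rests on a few compounds, and the source may have more. Where it says the series, first, only, none or still open, it means among the compounds named here.

Compound 1 `CN1CCCc2ccc(NC(=O)c3ccc(-c4ccccc4)cc3)cc21` gives 7.5 in a functional assay for antagonist activity at transient receptor potential cation channel subfamily V member 1 (Homo sapiens), read by FLIPR and calcium flux; on this read-out higher numbers stand for higher potency (the scale is a negative logarithm) and lower numbers for lower potency. Compound 2 `O=C(Nc1ccc2c(c1)NCCC2)c1ccc(-c2ccccc2)cc1` gives 7.7 in this assay, a step of a number 0.20 log units higher from compound 1 to compound 2 (within the scatter). Compound 3 `COc1cc(-c2ccccc2)ccc1C(=O)Nc1ccc2c(c1)N(C)CCC2` is reported in this assay only as a limit, < 6.8, not as a number. Compared with compound 1 that is a number at least 0.70 log units lower from compound 1 to compound 3 (beyond the scatter), so compound 3 stands at the limit of < 6.8 in this assay, at which 1 of the 3 values shown sits, the floor of the series as shown.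

Compound 4 `CN1CCCc2ccc(NC(=O)c3ccc(-c4ccccc4)cc3Cl)cc21` differs from compound 3 by chloro in place of methoxy on an aromatic carbon, the position being ortho to a large group and meta to a phenyl group. Going by the values given here, no step from methoxy to chloro at that carbon has been measured; the only step that touches it is the drop of a number at least 0.70 log units lower from compound 1 to compound 3 (beyond the scatter) when methoxy enters in place of hydrogen. For compound 4 the expectation is therefore a value between compound 3 and compound 1, estimated at 7 in this assay, with a range of 6.3 to 7.7. That estimate implies a step of a number at least 0.20 log units higher from compound 3 to compound 4 (that floor lies within the scatter), with a fair chance that the assay again reports only a limit.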

Compound 4, negative logarithm of the antagonist equilibrium constant: 7.1
Beside the measured number, compound 4's estimate is 0.10 log units below it; the measured number falls inside the stated range.
By their numbers in this assay, from the lowest: compound 4; then compounds 1 and 2 (each within the scatter of the next). At a limit, below all of these: compound 3.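

Going by these compounds alone, compound 4 gives the only number in this assay for a group other than hydrogen on this aromatic carbon, ortho to a large group and meta to a phenyl group, and chloro there costs potency against hydrogen: a number 0.40 log units lower from compound 1 to compound 4 (beyond the scatter). Chloro in place of methoxy reads as a number at least 0.30 log units higher from compound 3 to compound 4 (that floor lies within the scatter), which is only a floor, so the data do not show that the two groups differ beyond the scatter. Compound 3 remains a limit and not a number: the limit of < 6.8 in this assay, at which 1 of the 4 values shown sits.

On these data alone, whether a smaller or different group at this carbon, such as fluoro, nitrile or an amine, would stay closer to compound 1 remains open. Also open, as far as these compounds go, are the true distance between methoxy and chloro and whether chloro would have the same cost on compound 2, which carries hydrogen on the ring nitrogen.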